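This account rests on a few compounds, and the source may have more. Where it says the series, first, only, none or still open, it means among the compounds named here.

Working notes on the urea series. Compound 3 `COc1cc(Cl)cc(-c2nn(-c3cccc(NC(=O)Nc4ccc(Cl)c(Cl)c4)c3)cc2-c2ccncc2)c1` gives 3.51% in a functional assay on SK-MEL-5 cells (Homo sapiens) for inhibition, read by sulforhodamine B assay, with a stated time of 48 h, tested at 10 uM (a lower number here means a stronger effect, a higher number a weaker effect of the compound at the concentration tested), the highest of the three numbers in hand. Compound 1 `COc1cc(Cl)cc(-c2nn(-c3cccc(NC(=O)Nc4ccc(Cl)c(C(F)(F)F)c4)c3)cc2-c2ccncc2)c1` gives -71.2% in this assay, and compound 2 `COc1cc(Cl)cc(-c2nn(-c3cccc(NC(=O)Nc4cc(C(F)(F)F)cc(C(F)(F)F)c4)c3)cc2-c2ccncc2)c1` gives -79.4%; both lie far below compound 3, beyond the scatter. Within the data shown here, the one single-point step among the measured compounds is a number 74.7 percentage points higher from compound 1 to compound 3 (beyond the scatter), a large move upward on chloro in place of trifluoromethyl on an aromatic carbon.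

Compound 4 `COc1cc(Cl)cc(-c2nn(-c3cccc(NC(=O)Nc4cccc(C(F)(F)F)c4)c3)cc2-c2ccncc2)c1` has not yet been measured. It differs from compound 3 in one place: 3-(trifluoromethyl)phenyl in place of 3,4-dichlorophenyl on an amide-type nitrogen. This change runs the measured step in reverse, bringing trifluoromethyl back onto the aryl of the urea while the second chloro is lost. Both measured compounds carrying trifluoromethyl on that aryl, compound 1 at -71.2% and compound 2 at -79.4%, sit far below compound 3, beyond the scatter, so a large downward step is expected in this assay, with the loss of the second chloro leaving the exact size uncertain. Compound 4 is expected to give about -55% in this assay, within a range of -85% to -5%. The expected step of a number 58.5 percentage points lower from compound 3 to compound 4 (beyond the scatter) is thus estimated as a large move downward, beyond the scatter.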

Compound 4, a percentage reported as activity, at one concentration (the size of the read-out at that concentration, not a potency): 5.3%
Compound 4: the middle estimate sits 60.3 percentage points below what was measured; the whole stated range lies below it.
By their numbers in this assay, from the lowest: compounds 2 and 1 (each within the scatter of the next); then compounds 3 and 4 (each within the scatter of the next).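

In this assay the exchange of 3,4-dichlorophenyl for 3-(trifluoromethyl)phenyl on the amide-type nitrogen leaves the read-out in place: a number 1.8 percentage points higher from compound 3 to compound 4 (within the scatter), so trifluoromethyl on this aryl does not by itself bring the low numbers of compound 1 and compound 2. What separates those two from the new compound is the second group on the aryl: a number 84.7 percentage points higher from compound 2 to compound 4 (beyond the scatter) with hydrogen in place of trifluoromethyl, and a number 76.5 percentage points higher from compound 1 to compound 4 (beyond the scatter) with hydrogen in place of chloro. Among these four compounds the low numbers go with trifluoromethyl plus a second group on the aryl; compound 3 goes against a reading based on two aryl substituents alone, and compound 4 against one based on trifluoromethyl alone.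

Open, as far as these compounds go, is whether a second group other than chloro or trifluoromethyl, such as nitrile or fluoro, on the 3-(trifluoromethyl)phenyl would also give numbers as low as those of compound 1 and compound 2, and how an unsubstituted phenyl would compare. No measured data in hand bear on what lies behind this dependence on the pair of groups.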